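Para nitro for para bromo on a hydrazide

The source may hold more compounds than are shown below. What is called first, only, known or untested is meant among the compounds shown, and "the series" means these compounds.

The series rests on a shared core, seen in compound 2 `O=C(NNC(=O)c1ccccc1Br)c1ccc(-n2cccc2)cc1` and compound 3 `O=C(NNC(=O)c1ccc(-n2cccc2)cc1)c1ccc(Br)cc1`, with compound 1 `Cc1ccc(C)n1-c1ccc(C(=O)N/N=C/c2ccc(N(C)C)cc2)cc1` as a related member. In an ADME assay on A549 cells (Homo sapiens) for cytotoxicity, read by MTT assay, with a stated time of 72 h (a higher number here means a weaker inhibitor, a lower number a stronger inhibitor), compound 2 gives 201000 nM, and compound 3 gives 201000 nM; the step of no change at the digits printed from compound 2 to compound 3 (within the scatter) lies within the scatter. For compound 1 this assay records "not determined" (no result reported), so it adds no number. Compound 3 therefore stands level with compound 2 on the figures shown, with no compound separated from it beyond the scatter.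

Compound 4 `O=C(NNC(=O)c1ccc([N+](=O)[O-])cc1)c1ccc(-n2cccc2)cc1` differs from compound 3 in one place: nitro in place of bromo on an aromatic carbon. No measured step in this set compares nitro with bromo; the only step shown, no change at the digits printed from compound 2 to compound 3 (within the scatter), concerns where the bromo sits and is flat. Going by the values given here, that flat step is the sole guide, and it gives no reason to expect movement in either direction. Compound 4 is thus expected to sit with compound 3, a step of no change at the digits printed from compound 3 to compound 4 (within the scatter) being estimated. The estimate for compound 4 in this assay is 201000 nM, with a range from 100000 nM to 400000 nM.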

Compound 4, half-maximal inhibitory concentration: 198000 nM
The estimate for compound 4 lay 1.0-fold (0.01 log units) above the measured number; the range from low to high includes it.
By their numbers in this assay, from the lowest: compounds 4, 2 and 3 (each within the scatter of the next).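

In this assay, going by these compounds alone, the earlier compounds had only moved the bromo around its ring, whereas here the group itself is replaced, and nitro in place of bromo on an aromatic carbon gives a 1.0-fold lower number from compound 3 to compound 4 (0.01 log units; within the scatter) as its result. At this site, para to a large group, the read-out therefore tolerates an exchange of 1 heavy atom for 3 heavy atoms, and of 0 hydrogen-bond acceptors for 2 hydrogen-bond acceptors, without leaving the scatter, so the flatness seen so far extends from where the bromo sits to which group occupies the site, at least for these two groups. Nothing measured here on either group bears on why the number stays put.

The compounds shown leave open whether this site stays as flat with an amine, a carboxylic acid or a longer chain on the same aromatic carbon, as only bromo and nitro are compared there. They also leave open whether a change elsewhere on the shared core, away from this aromatic carbon, would move the number at all.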